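A few compounds are considered here, and "the series" means these few. Any claim that something is new, unique, unknown or untested is made for them only; others in the source may bear on it.

Of the compounds shown here, three have been measured in a functional assay on MDA-MB-468 cells (Homo sapiens) for inhibition, read by sulforhodamine B assay, with a stated time of 48 h; a higher number here means a weaker inhibitor of growth, a lower number a stronger inhibitor of growth. Compound 1 `COc1ccc(-c2[nH]c3ccccc3c2/C=C(\C#N)S(=O)(=O)c2ccccc2)cc1` gives < 10 nM in this assay, and this is a limit of the assay rather than a number, as noted in the limit of < 10 nM in this assay, at which 1 of the 3 values shown sits. Compound 2 `O=C(/C(=C\c1c(-c2ccccc2)[nH]c2ccccc12)S(=O)(=O)c1ccccc1)c1ccccc1` gives 4200 nM in this assay, and compound 3 `N#C/C(=C\c1c(-c2ccccc2)[nH]c2ccccc12)S(=O)(=O)c1ccccc1` gives 1900 nM. Among the two real numbers, compound 3 stands lowest; its nearest neighbour is compound 2, the change being a 2.2-fold lower number from compound 2 to compound 3 (0.34 log units; beyond the scatter). Compound 4 `N#C/C(=C\c1c(-c2ccccc2)[nH]c2ccccc12)C(=O)c1ccccc1` differs from compound 3 by benzoyl in place of phenylsulfonyl on a double-bonded chain carbon bound to a double-bonded chain carbon and a triple-bonded carbon. For the measured compounds named here, no measured step exchanges exactly these groups; the only step that also exchanged a benzoyl group, a 2.2-fold lower number from compound 2 to compound 3 (0.34 log units; beyond the scatter), was modest, while an at least 190-fold higher number from compound 1 to compound 3 (2.27 log units; beyond the scatter) concerns a different group and does not bear on this change. The step from compound 3 to compound 4 is therefore expected to be a 1.6-fold higher number from compound 3 to compound 4 (0.20 log units; within the scatter). Compound 4 is expected to give 3000 nM, in a range from 700 nM to 13000 nM.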

Compound 4, concentration for 50% growth inhibition: 5600 nM
Estimate against measurement, compound 4: 1.9-fold (0.27 log units) below; low and high end bracket the measured number.
By their numbers in this assay, from the lowest: compound 3; then compounds 2 and 4 (each within the scatter of the next). At a limit, below all of these: compound 1.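

The earlier compounds shown here changed only the partner of phenylsulfonyl; here phenylsulfonyl itself is exchanged, and benzoyl in its place gives a 2.9-fold higher number from compound 3 to compound 4 (0.47 log units; beyond the scatter) with the nitrile kept. Compound 2 and compound 4, which both carry benzoyl, lie within the scatter of each other, so compound 3, with phenylsulfonyl and nitrile together, gives the lowest number of the three. Nothing given here accounts for this change.

Still open, on these data alone, is how an amide or a carboxylic acid would fare on this carbon. Also open, as far as these compounds go, is whether methoxy on the aromatic ring would lower the number for compound 4.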